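The compounds below may be only part of what the source reports. "The series", "measured", "known", "first", "only" and "open" are said of these compounds alone.

For the measured compounds named here, compound 1 `Nc1nc(N)c2c(Cl)c(NC(=O)COc3ccc4ccccc4c3)ccc2n1` gives 7.85 in an assay for inhibition of Dihydrofolate reductase (Homo sapiens) (a lower number here means a less potent compound, a higher number a more potent compound, by a factor of ten per unit of this negative logarithm), the higher of the two numbers known so far. Compound 2 `Nc1nc(N)c2c(Cl)c(N)ccc2n1` gives 6.18 in this assay, a gap beyond the usual scatter. Compound 3 `Cc1c(NC(=O)COc2ccc3ccccc3c2)ccc2nc(N)nc(N)c12` has not yet been measured; it differs from compound 1 in one place: methyl in place of chloro on an aromatic carbon. Going by the values given here, no pair of measured compounds shows this change, so the expectation rests on compound 1 alone. The step is expected to be small and downward, a number 0.25 log units lower from compound 1 to compound 3 (within the scatter), close to the scatter. Compound 3 is therefore expected to give about 7.6, between 7 and 8.2.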

Compound 3, logarithm of the reciprocal of the active concentration, log(1/C): 7.82
Estimate against measurement, compound 3: 0.22 log units below; the measured number falls inside the stated range.
By their numbers in this assay, from the lowest: compound 2; then compounds 3 and 1 (each within the scatter of the next).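

The step, a number 0.03 log units lower from compound 1 to compound 3 (within the scatter), shows that in this assay chloro and methyl on this aromatic carbon cannot be told apart when the large group stands on the core. This position therefore tolerates either of these two single-atom groups, at least in this one pair of compounds. Nothing on hand explains this equivalence.

Going by these compounds, whether the two groups also match in the absence of the large group remains open, as does how a methoxy group, a bromo group or an amine would read at this position.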